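The source may hold more compounds than are shown below. What is called first, only, known or untested is meant among the compounds shown, and "the series" means these compounds.

In a functional assay on MCF7 cells (Homo sapiens) for cytotoxicity, read by colorimetric assay and neutral red uptake, with a stated time of 72 h (on this read-out lower numbers stand for stronger inhibition and higher numbers for weaker inhibition), compound 1 `CO[C@@H](C(=O)N[C@@H]1CC[C@H](O)CNC1=O)[C@H](O)[C@@H](O)[C@H](O)/C=C/C(C)(C)C` gives 80400 nM. Its diastereomer compound 2 `CO[C@@H](C(=O)N[C@H]1CC[C@@H](O)CNC1=O)[C@H](O)[C@@H](O)[C@H](O)/C=C/C(C)(C)C` gives 23400 nM in this assay; the step of a 3.4-fold lower number from compound 1 to compound 2 (0.54 log units; beyond the scatter) is beyond the scatter and rests on (the fact that compounds 1 and 2 differ only in the configuration as drawn). Compound 3 `CO[C@@H](C(=O)N[C@@H]1CCCCNC1=O)[C@@H]1OC(C)(C)O[C@H](/C=C/C(C)(C)C)[C@@H]1O` gives only a limit in this assay, > 150000 nM. Compound 2 thus stands at the lowest of the two numbers available, with compound 1 the nearest to it. Compound 4 `CO[C@@H](C(=O)N[C@H]1CC[C@H](O)CNC1=O)[C@H](O)[C@@H](O)[C@H](O)/C=C/C(C)(C)C` is the next variation on compound 2: the two compounds have the same atoms and bonds and differ only in configuration as drawn: 1 of 7 stereo elements differ; a stereocentre at a saturated ring carbon is drawn R in compound 2 and S in compound 4. For the measured compounds named here, the only measured step that bears on it is the one from compound 1 to compound 2, which moved the number by a 3.4-fold lower number from compound 1 to compound 2 (0.54 log units; beyond the scatter) when both ring stereocentres were inverted together; here a single one is inverted, and no measured pair shows which of the two earlier inversions carried the change. A step of similar size in either direction, or none beyond the scatter, is therefore possible. The step expected here is a 1.7-fold higher number from compound 2 to compound 4 (0.23 log units; within the scatter). Compound 4 is estimated at 40000 nM, with a range of 12000 nM to 130000 nM.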

Compound 4, half-maximal inhibitory concentration: 145000 nM
Beside the measured number, compound 4's estimate is 3.6-fold (0.56 log units) below it; measured number outside the range, above it.
By their numbers in this assay, from the lowest: compound 2; then compounds 1 and 4 (each within the scatter of the next). At a limit, above all of these: compound 3.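

The two ring stereocentres do not contribute equally in this assay: a single inversion gives a 6.2-fold higher number from compound 2 to compound 4 (0.79 log units; beyond the scatter), so one centre alone produces a step beyond the scatter, which the paired inversion could not show. The other single inversion gives a 1.8-fold higher number from compound 1 to compound 4 (0.26 log units; within the scatter), which stays within the scatter: the fact that compounds 1 and 4 differ only in the configuration as drawn. For the compounds shown here, the change at the first centre is therefore the one to follow, and the configuration there is the only difference behind its step: the fact that compounds 2 and 4 differ only in the configuration as drawn.

On these data alone, each inversion is read in only one setting of the other centre, so whether either effect holds in the remaining combination stays open. Also open, as far as these compounds go, is what an amine or a methoxy group in place of the ring hydroxyl would do to the number in this assay.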